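The source may report more compounds than this note shows. Statements on the series, on what has been measured and on what is new or still open speak of the compounds shown alone.

Measured in a functional assay on KB cells (Homo sapiens) for antiproliferative activity, read by MTT assay, with a stated time of 72 h; on this read-out higher numbers stand for weaker inhibition and lower numbers for stronger inhibition:
- Compound 1 `COc1ccc(-c2sc(C(=O)O)cc2-c2cc(OC)c(OC)c(OC)c2)cc1O`: 11200 nM
- Compound 2 `COc1ccc(-c2sccc2-c2cc(OC)c(OC)c(OC)c2)cc1[N+](=O)[O-]`: 10600 nM

Compound 2, at 10600 nM, lies within the usual scatter of compound 1, so these two numbers cannot be told apart. Compound 3 `COc1ccc(-c2sccc2-c2cc(OC)c(OC)c(OC)c2)cc1O` differs from compound 2 in one place, where hydroxy stands in place of nitro on an aromatic carbon: hydroxy in place of nitro on an aromatic carbon. Within the data shown here, no measured pair shows this change, so any forecast is uncertain. In this assay, a large move toward stronger inhibition is expected, beyond the scatter. The expected step is a 35-fold lower number from compound 2 to compound 3 (1.55 log units; beyond the scatter). For compound 3, the estimated value is 300 nM, with an expected range of 15 nM to 6000 nM.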

Compound 3, half-maximal inhibitory concentration: 6270 nM
Beside the measured number, compound 3's estimate is 21-fold (1.32 log units) below it, outside the stated range (above it).
By their numbers in this assay, from the lowest: compounds 3, 2 and 1 (each within the scatter of the next).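

In this assay, hydroxy in place of nitro on this aromatic carbon, ortho to a methoxy group, gives a 1.7-fold lower number from compound 2 to compound 3 (0.23 log units; within the scatter) and so does not separate the two groups. At a different place, hydrogen in place of carboxy on an aromatic carbon gives a 1.8-fold lower number from compound 1 to compound 3 (0.25 log units; within the scatter) and likewise separates nothing. No measurement offers an explanation for either result.

Still open, on these data alone, is whether an amine or a fluorine on the first aromatic carbon would also stay within the scatter. An amide in place of the carboxy group is equally untested by these compounds.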